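The compounds below may be only part of what the source reports. "The series", "measured", "known", "first", "only" and "open" are said of these compounds alone.

In a functional assay on HT-29 cells (Homo sapiens) for antiproliferative activity, read by MTT assay, with a stated time of 48 h (on this read-out lower numbers stand for stronger inhibition and higher numbers for weaker inhibition), the compounds measured so far give these values:

Compound 1 `Oc1ccc2c(c1)CCc1ccc(O)c(c1)Oc1ccc(cc1O)CCc1cccc(O)c1O2`: 15900 nM
Compound 2 `Oc1ccc2cc1Oc1ccc(cc1)/C=C\c1cccc(O)c1Oc1ccccc1CC2`: 9600 nM
Compound 3 `Oc1ccc2cc1Oc1ccc(cc1)CCc1ccc(O)c(c1)Oc1ccc(cc1)CC2`: 11500 nM

The account follows compound 3, whose value of 11500 nM lies within the usual scatter of both other numbers. The three compounds therefore cannot be ranked on these data, and the gap between compound 1 and compound 2 also stays within the scatter.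

The next compound is compound 4 `Oc1ccc2cc1Oc1ccc(cc1)CCc1ccc(O)c(c1)Oc1ccc(cc1O)CC2`, which differs from compound 3 by a single change: hydroxy in place of hydrogen on an aromatic carbon. Among the compounds with values here, no pair of measured compounds differs in one place only, so the data hold no direct precedent for this change. What they do show is a narrow spread: compound 1 at 15900 nM and compound 2 at 9600 nM both stay within the scatter of compound 3 despite their differing structures. On that basis, no change beyond the scatter is expected in this assay. The expected step is a 1.0-fold lower number from compound 3 to compound 4 (0.02 log units; within the scatter), with no firm direction. For compound 4 the estimated value is 11000 nM, with an expected range from 6000 nM to 20000 nM in this read-out.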

Compound 4, half-maximal inhibitory concentration: 14900 nM
Estimate against measurement, compound 4: 1.4-fold (0.13 log units) below, within the range that was stated.
By their numbers in this assay, from the lowest: compounds 2, 3, 4 and 1 (each within the scatter of the next).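

Within the data shown here, compound 4 supplies the first comparison in this assay between two compounds that differ in one place only: hydroxy in place of hydrogen on an aromatic carbon, ortho to a fused ring and meta to a fused ring, gives a 1.3-fold higher number from compound 3 to compound 4 (0.11 log units; within the scatter), and so this change at this position leaves the read-out within the usual scatter. Among these compounds, the earlier compounds could not show this, since none of them formed such a pair, and the single step now available gives the change no firm direction in this read-out. No measurement shown here bears on this result, so the step stands without any explanation.

What the compounds shown leave open is whether a hydroxy at another aromatic carbon of the shared core would behave in the same way, since this is the only position for which a single change can be read. Also open, from the compounds shown here alone, is whether a different group on this same aromatic carbon, such as a methoxy group, an amine or a carboxylic acid, would give a step beyond the scatter.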